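The source may hold more compounds than are shown below. What is called first, only, known or untested is meant among the compounds shown, and "the series" means these compounds.

Measured compounds in an ADME assay on microsomes from liver (Homo sapiens) for metabolic stability, tested at 2.5 uM; on this read-out lower numbers stand for slow clearance and higher numbers for fast clearance:

Compound 1, `O=S(=O)(c1ccc(F)c(Cl)c1)c1cnc2cc(F)ccc2c1-c1ccc(Cl)cc1`, gives 0.39 mL/min.
Compound 2, `Cc1ccc(S(=O)(=O)c2cnc3cc(F)ccc3c2-c2ccc(Cl)cc2)cc1C`, gives 7.88 mL/min.
Compound 3, `Cc1ccc(S(=O)(=O)c2cnc3cc(F)ccc3c2-c2cccc(F)c2)cc1C`, gives 3.71 mL/min.

Compound 2 and compound 1 share a core and differ in one group on the sulfonyl sulfur: 3-chloro-4-fluorophenyl in place of 3,4-dimethylphenyl on a sulfonyl sulfur. That single swap made a large step, a 20-fold lower number from compound 2 to compound 1 (1.31 log units; beyond the scatter). Compound 2 and compound 3 differ elsewhere, in the group carried on the core: 3-fluorophenyl in place of 4-chlorophenyl on an aromatic carbon. Here the step was modest, a 2.1-fold lower number from compound 2 to compound 3 (0.33 log units; beyond the scatter).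

Compound 4, `O=S(=O)(c1ccc(F)c(Cl)c1)c1cnc2cc(F)ccc2c1-c1cccc(F)c1`, has not yet been measured in this assay. It is built from compound 3 by the same change that turned compound 2 into compound 1: 3-chloro-4-fluorophenyl in place of 3,4-dimethylphenyl on a sulfonyl sulfur. The place of the change is described in the same words for both pairs, so it is the same change, only on a core that carries 3-fluorophenyl rather than 4-chlorophenyl.

For the measured compounds named here, there is only one earlier example of this change, so the expectation rests on that single step. Because compound 2 to compound 1 showed a 20-fold lower number from compound 2 to compound 1 (1.31 log units; beyond the scatter), a step of similar direction is expected from compound 3 to compound 4, estimated as a 15-fold lower number from compound 3 to compound 4 (1.17 log units; beyond the scatter), with some allowance for the step being smaller on this core. Compound 4 is therefore expected to give about 0.25 mL/min, estimated to fall between 0.08 mL/min and 0.9 mL/min.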

Compound 4, intrinsic clearance in a liver preparation (reported as CLH), per the amount of preparation that the assay uses: 0.25 mL/min
Compound 4: the middle estimate sits on the measured number at the digits printed, within the range that was stated.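

In this assay, putting 3-chloro-4-fluorophenyl in place of 3,4-dimethylphenyl on the sulfonyl sulfur gave a 15-fold lower number from compound 3 to compound 4 (1.17 log units; beyond the scatter), and the size of this step held from one core to the other: the same change on two cores in this assay, a 20-fold lower number (1.31 log units; beyond the scatter) from compound 2 to compound 1 and a 15-fold lower number (1.17 log units; beyond the scatter) from compound 3 to compound 4, 1.4-fold (0.13 log units) apart, within the scatter of two such steps The second change, 3-fluorophenyl in place of 4-chlorophenyl, gave a 1.6-fold lower number from compound 1 to compound 4 (0.19 log units; within the scatter), so on its own it cannot be told from repeat noise in this pair, yet it does not disagree with its earlier example: the same change on two cores in this assay, a 2.1-fold lower number (0.33 log units; beyond the scatter) from compound 2 to compound 3 and a 1.6-fold lower number (0.19 log units; within the scatter) from compound 1 to compound 4, 1.4-fold (0.13 log units) apart, within the scatter of two such steps Within these four compounds, then, each change gave much the same step whichever form of the other group was present, but that rests on just two examples of each change and does not show that the steps would hold on a different core, nor does it explain why the number falls.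

The compounds shown leave open whether the chlorine, the fluorine or both together account for the large step, and a 3-chlorophenyl or a 4-fluorophenyl group on the sulfonyl sulfur would separate them. Also open, as far as these compounds go, is how the series would respond to a quite different group in that place, such as an amine or a carboxylic acid.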